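Fluoro for chloro on the fused ring of compound 1

A few compounds are considered here, and "the series" means these few. Any claim that something is new, unique, unknown or untested is made for them only; others in the source may bear on it.

Measured compounds:
- compound 1 `CCn1c(CNc2ccccc2)nnc1SCc1nc2cc(Cl)ccc2o1`: 2300 nM
- compound 2 `CCn1c(CNc2ccccc2)nnc1SCC(=O)Nc1ccc(C(=O)NC)cc1`: > 10000 nM, a limit of the assay
- compound 3 `CCn1c(CNc2ccccc2)nnc1SCC(=O)Nc1ccccc1`: > 10000 nM, a limit of the assay

Among the measured compounds shown here, in an assay on isolated protein for inhibition of long-chain fatty acid transport protein 1 (Mus musculus) (a higher number here means a weaker inhibitor, a lower number a stronger inhibitor), compound 1 holds the only readable number of the set; the other two entries are the limit of > 10000 nM in this assay, at which 2 of the 3 values shown sit. For the measured compounds named here, the single measured step, a step that the two limits leave unreadable from compound 2 to compound 3, concerns a change on the amide-linked phenyl part and yields no readable size, so it carries nothing over to the fused-ring halogen.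

Compound 4 `CCn1c(CNc2ccccc2)nnc1SCc1nc2cc(F)ccc2o1` differs from compound 1 by fluoro in place of chloro on an aromatic carbon. Going by the values given here, no measured step in this assay speaks to a halogen exchange at that place, so the expectation rests on compound 1 alone. A small weakening is expected, a 1.7-fold higher number from compound 1 to compound 4 (0.24 log units; within the scatter), though a step within the scatter would not surprise. Compound 4 is therefore estimated at 4000 nM in this assay, in a range from 1500 nM to 10000 nM.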

Compound 4, half-maximal inhibitory concentration: 7800 nM
Beside the measured number, compound 4's estimate is 2.0-fold (0.29 log units) below it; low and high end bracket the measured number.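

In this assay, fluoro in place of chloro on an aromatic carbon gives a 3.4-fold higher number from compound 1 to compound 4 (0.53 log units; beyond the scatter). Among the compounds shown here, this is the first readable step, and it shows that the identity of the halogen at this place registers in the assay, with chloro giving the stronger inhibitor of this pair. No measured property among the compounds shown accounts for the size of this step.

As far as these compounds go, whether hydrogen, bromo, methoxy or trifluoromethyl on this aromatic carbon would match or improve on chloro remains open, as does the effect of moving the chloro to another carbon of that ring. The phenyl on the aminomethyl arm is unsubstituted throughout, so the effect of a nitrile or a carboxylic acid there is also unresolved.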